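This account rests on a few compounds, and the source may have more. Where it says the series, first, only, none or still open, it means among the compounds named here.

Of the compounds shown here, three have been measured in a toxicity assay on MRC5 cells (Homo sapiens) for cytotoxicity, read by MTT assay, with a stated time of 72 h; a higher number here means that more compound is needed for the effect, a lower number that less compound is needed. Compound 1, `Cn1cc(/C=N/NC(N)=S)c2ccccc21`, gives only a limit of the assay, > 200000 nM. Compound 2, `CCCCn1cc(/C=N/NC(N)=S)c2cccc(C)c21`, gives 31000 nM in this assay. Compound 3, `CCOc1ccc(/C=N/NC(N)=S)c2ccccc12`, likewise reaches only the limit of the assay, > 200000 nM. Compound 3 thus stands where most of the shown values stand, at the limit of > 200000 nM in this assay, at which 2 of the 3 values shown sit, and no measured step joins it to either other compound; the reading of compound 2 is the one number that falls inside the range of this assay.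

Compound 4, `COCOc1ccc(/C=N/NC(N)=S)c2ccccc12`, has not yet been measured. It differs from compound 3 by methoxy in place of methyl on a saturated chain carbon bound to an oxygen on an aromatic ring, which is methoxy in place of methyl on a saturated chain carbon bound to an oxygen on an aromatic ring. Within the data shown here, no measured step between two compounds is available, so nothing charts the effect of this change on its own. Since compound 3 gives only the limit > 200000 nM, the step of a number no higher from compound 3 to compound 4 (the limit leaves the size open) is expected to be none beyond the scatter, with a limit the most likely outcome. Compound 4 is estimated at 200000 nM, between 60000 nM and 500000 nM.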

Compound 4, half-maximal effective concentration: 126000 nM
Estimate against measurement, compound 4: 1.6-fold (0.20 log units) above; measured number inside the range.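

Replacing methyl by methoxy on a saturated chain carbon bound to an oxygen on an aromatic ring gives, in this assay, an at least 1.5-fold lower number from compound 3 to compound 4 (0.20 log units; that floor lies within the scatter). With that floor inside the scatter, the step does not establish that this change alters the reading, yet it does show that compound 4 gives a number at this position, where compound 3 gave only a limit, and so a measured reference now exists for further changes here. Compound 1 and compound 3 still give only a limit, so the limit remains as common as any other reading in the set: the limit of > 200000 nM in this assay, at which 2 of the 4 values shown sit.

Going by these compounds, the true size of the step stays open, since one of its two ends is a limit and not a number. On these data alone, it also remains unknown whether an amine, a carboxylic acid or a longer chain in place of methoxy on that saturated chain carbon would give a different reading, and whether the change from methyl to methoxy would have a similar outcome on another core.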